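The source may hold more compounds than are shown below. What is called first, only, known or untested is meant among the compounds shown, and "the series" means these compounds.

Measured so far in a functional assay on NCI-H322M cells (Homo sapiens) for inhibition, read by sulforhodamine B assay, with a stated time of 48 h; a lower number here means that less compound is tolerated, a higher number that more compound is tolerated:
Compound 1, `O=C(Nc1cccc(-n2cc(-c3ccncc3)c(-c3ccc(Cl)c(O)c3)n2)c1)Nc1cccc(C(F)(F)F)c1`, gives > 32500 nM, which is a limit of the assay.
Compound 2, `COc1cc(-c2nn(-c3cccc(NC(=O)Nc4cc(C(F)(F)F)cc(C(F)(F)F)c4)c3)cc2-c2ccncc2)ccc1Cl`, gives 29900 nM.
Compound 3, `COc1cc(-c2nn(-c3cccc(NC(=O)Nc4cccc(C(F)(F)F)c4)c3)cc2-c2ccncc2)ccc1Cl`, gives > 50000 nM, which is a limit of the assay.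

Among the compounds with values here, compound 2 therefore holds the only number in this assay; the two other values are limits. The compound to be measured is compound 4, `O=C(Nc1cccc(-n2cc(-c3ccncc3)c(-c3ccc(Cl)c(O)c3)n2)c1)Nc1cc(C(F)(F)F)cc(C(F)(F)F)c1`. It differs from compound 2 in one place: hydrogen in place of methyl on an oxygen on an aromatic ring. Within the data shown here, two measured steps bear on this. The same change run the other way, a step that the two limits leave unreadable from compound 1 to compound 3, cannot be read. Compound 1 stands at the limit of > 32500 nM in this assay, at which 1 of the 3 values shown sits. Compound 3 stands at the limit of > 50000 nM in this assay, at which 1 of the 3 values shown sits. The other step, an at least 1.6-fold higher number from compound 2 to compound 3 (0.22 log units; that floor lies within the scatter), concerns the trifluoromethyl rather than the oxygen, and its floor lies within the scatter. No readable precedent for the change itself exists, and compound 2 already sits close to the top of what this assay reports. The chemist thus expects no step beyond the scatter, a 1.2-fold higher number from compound 2 to compound 4 (0.07 log units; within the scatter), and a fair chance that compound 4 returns only a limit. His estimate for compound 4 is 35000 nM, between 15000 nM and 80000 nM.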

Compound 4, concentration lethal to 50% of the cells: 23600 nM
For compound 4 the middle estimate is 1.5-fold (0.17 log units) above the measured one, and the stated range covers the measured number.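

Within the data shown here, with compound 4, replacing 4-chloro-3-methoxyphenyl with 4-chloro-3-hydroxyphenyl has a readable size for the first time in this assay: the result is a 1.3-fold lower number from compound 2 to compound 4 (0.10 log units; within the scatter). Trifluoromethyl in place of hydrogen on an aromatic carbon gives an at least 1.3-fold lower number from compound 1 to compound 4 (0.13 log units; that floor lies within the scatter), a floor and not a full size, set by the limit of compound 1. This change can now be compared on two cores, though neither floor clears the scatter: the same change on two cores in this assay, an at least 1.6-fold higher number (0.22 log units; that floor lies within the scatter) from compound 2 to compound 3 and an at least 1.3-fold higher number (0.13 log units; that floor lies within the scatter) from compound 4 to compound 1; the limit leaves it open whether they differ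

Going by these compounds, the step that joins the two limits remains unreadable, so the effect of replacing methoxy with hydroxy on the core of compound 1 stays open. Also open, on these data alone, is whether an ethyl group on that oxygen, or an amine in place of the hydroxy, would shift the number in this assay beyond the scatter.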